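Oxime ether series at the alpha-adrenergic receptor: compound 3

The source may hold more compounds than are shown below. What is called first, only, known or untested is meant among the compounds shown, and "the series" means these compounds.

Measured so far:
compound 1 `CO/N=C(\C)c1ccccc1NCC1=NCCN1`, 92%
compound 2 `CCO/N=C(\C)c1ccccc1NCC1=NCCN1`, 102%

In a functional assay for activation of Alpha-1A adrenergic receptor (Homo sapiens), read by calcium flux (on this read-out higher numbers stand for larger maximal responses and lower numbers for smaller maximal responses), compound 2 stands highest of the two numbers, but its nearest neighbour, compound 1, is within the scatter: a number 10 percentage points higher from compound 1 to compound 2 (within the scatter). Compound 2 therefore cannot be called the more active of the pair.

Compound 3 `CC/C(=N\OC)c1ccccc1NCC1=NCCN1` is not yet measured. It differs from compound 2 in that the two have the same atoms, joined differently: a group of 6 heavy atoms (4 carbon, 1 nitrogen, 1 oxygen; no ring) in place of a group of 6 heavy atoms (4 carbon, 1 nitrogen, 1 oxygen; no ring), on an aromatic carbon. Going by the values given here, no measured step covers this rearrangement; the only step known, the methyl in place of hydrogen on the saturated chain carbon bound to oxygen, gave a number 10 percentage points higher from compound 1 to compound 2 (within the scatter), a change within the scatter. With both measured compounds at a full response and no step beyond the scatter in the series, no shift beyond the scatter is expected for compound 3 in this assay: a number 7 percentage points lower from compound 2 to compound 3 (within the scatter). Compound 3 is estimated at 95%, in the range 75% to 110%.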

Compound 3, largest response reached (reported as maximum), in percent of the reference or control that the assay uses: 112%
Beside the measured number, compound 3's estimate is 17 percentage points below it; measured number outside the range, above it.
By their numbers in this assay, from the lowest: compounds 1, 2 and 3 (each within the scatter of the next, the first and the last beyond it).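

In this assay, going by these compounds alone, a methyl in place of hydrogen on the saturated chain carbon bound to the carbon with a double bond to nitrogen gives a number 20 percentage points higher from compound 1 to compound 3 (beyond the scatter), the only step that clears the scatter, whereas the same addition at the oxygen end stays inside it, with a number 10 percentage points higher from compound 1 to compound 2 (within the scatter) as the printed step. The rearrangement of the same atoms on the aromatic carbon gives a number 10 percentage points higher from compound 2 to compound 3 (within the scatter), so compound 2 and compound 3 cannot be ranked against each other. No data are available that would explain these differences.

From the compounds shown here alone, whether a propyl chain on the carbon with the double bond to nitrogen would extend this step remains open. Also open, going by these compounds, is how a benzyl group on the oxygen would affect the response of compound 3.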